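Anilide variation on a shared triazole thioacetamide core

A few compounds are considered here, and "the series" means these few. Any claim that something is new, unique, unknown or untested is made for them only; others in the source may bear on it.

Compound 2 `COc1ccccc1NC(=O)CSc1nnc(-c2ccoc2C)n1Cc1ccco1` carries a 2-methoxyphenyl on the amide nitrogen. Within the data shown here, in a functional assay on CHO cells for antagonist activity at Orexin receptor type 2 (Homo sapiens), read by FLIPR and calcium flux (on this read-out higher numbers stand for weaker inhibition and lower numbers for stronger inhibition), compound 2 gives 501 nM, which is the only actual number so far. Compound 1 `Cc1cccc(C)c1NC(=O)CSc1nnc(-c2ccoc2C)n1Cc1ccco1` is the 2,6-dimethylphenyl counterpart. In this assay compound 1 yields only a limit of the assay, > 15800 nM, and not a number, as shown by the limit of > 15800 nM in this assay, at which 1 of the 2 values shown sits. Among the measured compounds shown here, the single measured step is an at least 31-fold lower number from compound 1 to compound 2 (1.49 log units; beyond the scatter), so the group on the amide nitrogen clearly matters, though with only two points no pattern beyond them can be claimed.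

Compound 3 `CC(=O)c1cccc(NC(=O)CSc2nnc(-c3ccoc3C)n2Cc2ccco2)c1` is the next variation: 3-acetylphenyl in place of 2-methoxyphenyl on an amide-type nitrogen. For the measured compounds named here, no measured step involves a 3-acetylphenyl, and the step from compound 1 to compound 2 concerns a different pair of groups, so it gives direction only loosely. The expectation for compound 3 is therefore a modest weakening, a 3.0-fold higher number from compound 2 to compound 3 (0.48 log units; beyond the scatter), with wide uncertainty. Compound 3 is estimated at 1500 nM, within a range from 300 nM to 8000 nM.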

Compound 3, inhibition constant: 316 nM
The estimate for compound 3 lay 4.7-fold (0.68 log units) above the measured number, within the range that was stated.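

In this assay the exchange of 2-methoxyphenyl for 3-acetylphenyl on the amide-type nitrogen gives a 1.6-fold lower number from compound 2 to compound 3 (0.20 log units; within the scatter) and so shows two differently substituted phenyl groups reading alike at this position. A second group now also gives an at least 50-fold lower number from compound 1 to compound 3 (1.69 log units; beyond the scatter) and so the large gap seen earlier no longer rests on 2-methoxyphenyl alone; among the three compounds, only the 2,6-dimethylphenyl of compound 1 stands apart from the other two. Compound 1 still gives a limit of the assay and not a number: the limit of > 15800 nM in this assay, at which 1 of the 3 values shown sits.

Going by these compounds, three anilides fix no trend on this nitrogen, and it stays open whether the gap to the 2,6-dimethylphenyl group needs both methyl groups, which a 2-methylphenyl or a plain phenyl on the same nitrogen would help to settle. Also open, on these data alone, is how a carboxylic acid or an amine on the phenyl ring would read, and whether the picture at this position holds when the groups elsewhere on the shared core change.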